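Ring amine replacing butylamino on the core

The source may report more compounds than this note shows. Statements on the series, on what has been measured and on what is new or still open speak of the compounds shown alone.

Compound 1 `CCCCNc1nc(C(F)(F)F)ccc1CNC(=O)C(C)c1ccc(NS(C)(=O)=O)c(F)c1` is the anchor of this pair of notes. Among the compounds with values here, in a functional assay on CHO-K1 cells for antagonist activity at transient receptor potential cation channel subfamily V member 1 (Homo sapiens), read by FLIPR (on this read-out higher numbers stand for weaker inhibition and lower numbers for stronger inhibition), compound 1 gives 293 nM, the highest of the two numbers so far. Within the data shown here, compound 2 `CC(C(=O)NCc1ccc(C(F)(F)F)nc1N1CC=CCC1)c1ccc(NS(C)(=O)=O)c(F)c1` differs from it in one place only, and in this assay compound 2 gives 12.1 nM; the step of a 24-fold lower number from compound 1 to compound 2 (1.38 log units; beyond the scatter) is the only measured step in the set and is large.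

Compound 3 `CC(C(=O)NCc1ccc(C(F)(F)F)nc1N1CCC(c2ccccc2)CC1)c1ccc(NS(C)(=O)=O)c(F)c1` has not yet been measured in this assay. Its change from compound 1 is 4-phenylpiperidin-1-yl in place of butylamino on an aromatic carbon. The step from compound 1 to compound 2 is the one that bears on it, since both changes exchange the same butylamino for a six-membered non-aromatic ring with one hetero atom on the same aromatic carbon; compound 3 additionally carries a six-membered aromatic ring of carbon only on that ring. Among the measured compounds shown here, no measured step speaks to that extra ring.

Given the large lowering in a 24-fold lower number from compound 1 to compound 2 (1.38 log units; beyond the scatter), compound 3 is expected to show a step of about a 20-fold lower number from compound 1 to compound 3 (1.29 log units; beyond the scatter) in this assay. The estimate for compound 3 is 15 nM, with a range from 4 nM to 60 nM.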

Compound 3, half-maximal inhibitory concentration: 25 nM
For compound 3 the middle estimate is 1.7-fold (0.22 log units) below the measured one, and the stated range covers the measured number.
By their numbers in this assay, from the lowest: compound 2; then compound 3; then compound 1.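

The position next to the ring nitrogen tolerates a far larger group than the ring of compound 2 without losing the advantage over butylamino: in this assay, 4-phenylpiperidin-1-yl gives a 12-fold lower number from compound 1 to compound 3 (1.07 log units; beyond the scatter), so the lower number is not confined to the smaller ring amine. Enlarging the group has only a modest cost, seen in a 2.1-fold higher number from compound 2 to compound 3 (0.32 log units; beyond the scatter), but this step adds the six-membered aromatic ring of carbon only and also exchanges one non-aromatic ring for another, so the cost cannot be assigned to the aromatic ring alone. No measurement at hand bears on why either step has its size.

The compounds shown leave open how a plain piperidin-1-yl group would compare, which would separate the two parts of the change from compound 2 to compound 3, and whether a 4-benzylpiperidin-1-yl or 3-phenylpiperidin-1-yl group would be tolerated as well. They also leave open whether the ring itself is needed, which a morpholin-4-yl group or an open-chain dibutylamino group on the same aromatic carbon would test.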